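From 3-methylpiperidin-1-yl to (5-methylpyridin-2-yl)amino on the carbonyl

The source may report more compounds than this note shows. Statements on the series, on what has been measured and on what is new or still open speak of the compounds shown alone.

In a functional assay on BXPC-3 cells (Homo sapiens) for antiproliferative activity, read by MTT assay, with a stated time of 48 h (on this read-out higher numbers stand for weaker inhibition and lower numbers for stronger inhibition), compound 1 `Cc1c(C(=O)NCCCN(C)C)oc2ccc(N(Cc3ccc(Br)cc3)S(=O)(=O)c3ccc(Br)cc3)cc12` gives 2020 nM and compound 3 `Cc1c(C(=O)N2CCCC(C)C2)oc2ccc(N(Cc3ccc(Br)cc3)S(=O)(=O)c3ccc(Br)cc3)cc12` gives 16700 nM, the higher of these two numbers. Compound 2 `Cc1c(C(=O)NCCS(C)(=O)=O)oc2ccc(N(Cc3ccc(Br)cc3)S(=O)(=O)c3ccc(Br)cc3)cc12` gives > 40000 nM, which is a limit of the assay and not a number.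

Compound 4 `Cc1ccc(NC(=O)c2oc3ccc(N(Cc4ccc(Br)cc4)S(=O)(=O)c4ccc(Br)cc4)cc3c2C)nc1` keeps the shared core but carries (5-methylpyridin-2-yl)amino in place of 3-methylpiperidin-1-yl on a carbonyl carbon. Two measured steps change the group at this same carbonyl carbon, and both lie beyond the scatter: an 8.3-fold higher number from compound 1 to compound 3 (0.92 log units; beyond the scatter) and an at least 2.3-fold lower number from compound 2 to compound 3 (0.37 log units; beyond the scatter). None of the three measured compounds has an aromatic ring in this group, so these steps offer only a rough guide. The entering group lacks the dimethylamino group of compound 1, which gives 2020 nM, so the result is expected to stay close to compound 3, which gives 16700 nM. The expected step is a 1.2-fold lower number from compound 3 to compound 4 (0.08 log units; within the scatter), with no change beyond the scatter. For compound 4, the estimated value is 14000 nM, within an expected range from 4000 nM to 40000 nM.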

Compound 4, half-maximal inhibitory concentration: > 40000 nM
Compound 4: only a limit was reported; the forecaster's own chance of this, stated with the estimate: 25%; middle value at least 2.8-fold (0.45 log units) from the limit.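

In this assay, replacing the non-aromatic ring of 3-methylpiperidin-1-yl with the aromatic ring of (5-methylpyridin-2-yl)amino, the first aromatic ring in this group, gives an at least 2.3-fold higher number from compound 3 to compound 4 (0.37 log units; beyond the scatter), so this ring does not bring the number down. Measured against the side chain of compound 1, the change is an at least 19-fold higher number from compound 1 to compound 4 (1.29 log units; beyond the scatter), and compound 1 keeps the lowest number of the four compounds. Compound 4 gives a limit of the assay and not a number, as compound 2 does, so the step between these two cannot be read: the limit of > 40000 nM in this assay, at which 2 of the 4 values shown sit.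

The compounds shown leave open whether the dimethylamino group or the propyl chain matters more in compound 1; a shorter chain ending in the same dimethylamino group, or a propyl chain ending in a carboxylic acid, would separate the two. They also leave open whether a plain phenyl ring on the amide-type nitrogen would behave like 5-methylpyridin-2-yl.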